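The source may report more compounds than this note shows. Statements on the series, on what has been measured and on what is new or still open speak of the compounds shown alone.

Compound 1 `C=CCn1c(=O)/c(=C\c2cccc(Cl)c2)[nH]c(=O)/c1=C\c1ccccc1OC` gives 4500 nM in a functional assay on HL-60 cells (Homo sapiens) for cytotoxicity, read by CCK-8 assay, with a stated time of 72 h; on this read-out higher numbers stand for weaker inhibition and lower numbers for stronger inhibition.
Compound 2 `C=CCn1c(=O)/c(=C\c2ccccc2Cl)[nH]c(=O)/c1=C\c1ccccc1OC` gives 4200 nM.
Compound 3 `C=CCn1c(=O)/c(=C\c2cccc(Br)c2)[nH]c(=O)/c1=C\c1ccccc1OC` gives 5200 nM.

Compound 3 carries the highest of the three numbers, yet a 1.2-fold higher number from compound 1 to compound 3 (0.06 log units; within the scatter) and a 1.2-fold higher number from compound 2 to compound 3 (0.09 log units; within the scatter) both stay within the scatter, so no order among the three can be read. Compound 4 `C=CCn1c(=O)/c(=C\c2ccccc2F)[nH]c(=O)/c1=C\c1ccccc1OC` carries 2-fluorophenyl in place of 3-bromophenyl on a double-bonded chain carbon bound to an aromatic carbon. For the measured compounds named here, two measured steps bear on this change: a 1.1-fold lower number from compound 1 to compound 2 (0.03 log units; within the scatter) exchanges 3-chlorophenyl for 2-chlorophenyl, and a 1.2-fold higher number from compound 1 to compound 3 (0.06 log units; within the scatter) exchanges chloro for bromo, each within the scatter. Compound 4 combines a shift of the halogen's ring position with a halogen exchange, and neither kind of change has so far moved the number, so the step of a 1.2-fold lower number from compound 3 to compound 4 (0.06 log units; within the scatter) is expected to remain within the scatter. Compound 4 is therefore estimated at 4500 nM, with a range from 2000 nM to 10000 nM.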

Compound 4, half-maximal inhibitory concentration: 18500 nM
The estimate for compound 4 lay 4.1-fold (0.61 log units) below the measured number; the measured number lies above the stated range.
By their numbers in this assay, from the lowest: compounds 2, 1 and 3 (each within the scatter of the next); then compound 4.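

Fluoro is the first change at this place to move the number: with 2-fluorophenyl in place of 2-chlorophenyl, the result is a 4.4-fold higher number from compound 2 to compound 4 (0.64 log units; beyond the scatter), whereas the earlier changes among chloro and bromo groups stayed within the scatter. Steps of similar size separate compound 4 from the 3-halophenyl compounds, namely a 4.1-fold higher number from compound 1 to compound 4 (0.61 log units; beyond the scatter) and a 3.6-fold higher number from compound 3 to compound 4 (0.55 log units; beyond the scatter), so all three other compounds read lower than compound 4. No evidence accounts for this difference. The compounds shown leave open whether 3-fluorophenyl would behave like 2-fluorophenyl, and how plain phenyl or 2-methylphenyl would read here.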